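A Fluorophenyl Variant Follows Three Closely Matched Analogues

The source may hold more compounds than are shown below. What is called first, only, known or untested is meant among the compounds shown, and "the series" means these compounds.

Compound 1 `Cc1cccc(NC(=O)Nc2nnc(Sc3ncnc4scc(-c5ccncc5)c34)s2)c1` gives 27200 nM in a functional assay on T47D cells (Homo sapiens) for antiproliferative activity, read by MTT assay, with a stated time of 48 h; a lower number here means a stronger inhibitor, a higher number a weaker inhibitor. Compound 2 `O=C(Nc1cccc(Cl)c1)Nc1nnc(Sc2ncnc3scc(-c4ccncc4)c23)s1` gives 43900 nM. Compound 3 `Cc1ccc(NC(=O)Nc2nnc(Sc3ncnc4scc(-c5ccncc5)c34)s2)cc1Cl` gives 34800 nM.

Among these three numbers compound 3 stands second highest. Its nearest neighbour is compound 2, with a 1.3-fold lower number from compound 2 to compound 3 (0.10 log units; within the scatter), and its furthest is compound 1, with a 1.3-fold higher number from compound 1 to compound 3 (0.11 log units; within the scatter). Compound 4 `O=C(Nc1ccc(F)cc1)Nc1nnc(Sc2ncnc3scc(-c4ccncc4)c23)s1` differs from compound 3 by 4-fluorophenyl in place of 3-chloro-4-methylphenyl on an amide-type nitrogen. Among the measured compounds shown here, the steps that bear on this change all alter the same phenyl group: a 1.6-fold higher number from compound 1 to compound 2 (0.21 log units; within the scatter) and a 1.3-fold lower number from compound 2 to compound 3 (0.10 log units; within the scatter), each within the scatter. On that basis compound 4 is expected to show a 1.0-fold higher number from compound 3 to compound 4 (0.00 log units; within the scatter) in this assay, nothing beyond the scatter. The estimate for compound 4 is 35000 nM, expected to fall between 15000 nM and 80000 nM.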

Compound 4, half-maximal inhibitory concentration: 18900 nM
For compound 4 the middle estimate is 1.9-fold (0.27 log units) above the measured one, within the range that was stated.
By their numbers in this assay, from the lowest: compounds 4, 1, 3 and 2 (each within the scatter of the next, the first and the last beyond it).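

Among the compounds shown here, with 4-fluorophenyl on the amide-type nitrogen, this position gives its only step beyond the scatter in this assay, with a 2.3-fold lower number from compound 2 to compound 4 (0.37 log units; beyond the scatter), although the step is modest. The other two steps involving this group stay within the scatter, with a 1.8-fold lower number from compound 3 to compound 4 (0.27 log units; within the scatter) and a 1.4-fold lower number from compound 1 to compound 4 (0.16 log units; within the scatter), so the change separates only compound 4 and compound 2. No measurement shown here bears on this result. As far as these compounds go, it remains open whether an unsubstituted phenyl, or a phenyl carrying an amine or a carboxylic acid, would lower the number further.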